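The compounds below may be only part of what the source reports. "The series", "measured", "known", "first", "only" and "open" are said of these compounds alone.

Working notes on the series.

Compound 3 `CCCc1cc(N)c2cc(NC(=O)/C=C/c3ccc(Cl)cc3Cl)ccc2n1` is the reference point for this step. In an assay on isolated protein for displacement of a labelled ligand from melanin-concentrating hormone receptor 1 (Homo sapiens) (on this read-out higher numbers stand for weaker inhibition and lower numbers for stronger inhibition), compound 3 gives 6.6 nM. Alongside it stand compound 1 `CCCc1cc(NC)c2cc(NC(=O)/C=C/c3ccc(C(F)(F)F)cc3)ccc2n1`, which in this assay gives 1.5 nM, and compound 2 `CCCc1cc(N2CCCC2)c2cc(NC(=O)/C=C/c3ccc(C(F)(F)F)cc3)ccc2n1`, which in this assay gives 17 nM. On these three numbers compound 3 sits second highest: its value lies closest to that of compound 2 and furthest from that of compound 1, with both gaps beyond the scatter.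

Among the measured compounds shown here, the one measured step in the set is an 11-fold higher number from compound 1 to compound 2 (1.05 log units; beyond the scatter). That step concerns the amine on the core and leaves the cinnamamide aryl ring untouched, so it says nothing direct about the change under study here.

Compound 4 `CCCc1cc(N)c2cc(NC(=O)/C=C/c3ccc(F)cc3)ccc2n1` differs from compound 3 by 4-fluorophenyl in place of 2,4-dichlorophenyl on a double-bonded chain carbon bound to a double-bonded chain carbon. Compounds 1 and 3 carry different aryl rings but also differ at the amine, so their values cannot be separated into a clean aryl-ring step. With no measured comparison bearing on this change, the expectation rests on the general observation that replacing two ring substituents with a single small one tends to cost some affinity; a moderate weakening is therefore estimated for compound 4, expressed as a 2.3-fold higher number from compound 3 to compound 4 (0.36 log units; beyond the scatter). The value for compound 4 in this assay is estimated at 15 nM, with a range of 4 nM to 60 nM.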

Compound 4, half-maximal inhibitory concentration: 130 nM
Compound 4: middle estimate off by 8.7-fold (0.94 log units), on the low side; measured number outside the range, above it.
By their numbers in this assay, from the lowest: compound 1; then compound 3; then compound 2; then compound 4.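

The aryl ring on the double-bonded chain carbon carries real weight in this assay: with the amine on the core held fixed, 4-fluorophenyl in place of 2,4-dichlorophenyl gives a 20-fold higher number from compound 3 to compound 4 (1.29 log units; beyond the scatter). Among the compounds shown here, this is the only measured comparison in the set that isolates this ring, and it shows that the position is not indifferent to the change. The step is large, as is the one at the amine on the core (an 11-fold higher number from compound 1 to compound 2 (1.05 log units; beyond the scatter)), so both places shown to vary can move the number substantially, and nothing measured here explains the loss at the aryl ring.

The change alters two things at once, since the chlorine count goes from 2 to 0 and a fluorine enters, so the compounds shown cannot say how much of the step belongs to the 2-chloro group and how much to the group at the 4 position of the ring. From the compounds shown here alone, a 4-chlorophenyl or a 2-chlorophenyl analogue on the same core would separate these contributions, and whether the step holds with the methylamino group on the core also remains open.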